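The compounds below may be only part of what the source reports. "The series", "measured", "known", "first", "only" and "open" are said of these compounds alone.

This study looks at two compounds built on the same shared core and asks how a third might behave. The measurement is a functional assay on MCF7 cells (Homo sapiens) for cytotoxicity, read by MTT assay, with a stated time of 72 h; a higher number here means a weaker inhibitor, a lower number a stronger inhibitor. Compound 1, with the structure `Cc1c(C)c2c(c(C)c1OC(=O)CCC(=O)O)CCC(C)(C(=O)NC1CC(C)(C)N([O])C(C)(C)C1)O2`, gives no number: in this assay compound 1 reaches only a limit, > 300000 nM. Compound 2, with the structure `Cc1c(C)c2c(c(C)c1OC(=O)CCC(=O)NC1CC(C)(C)N([O])C1(C)C)CCC(C)(C(=O)NC1CC(C)(C)N([O])C1(C)C)O2`, does give a number; in this assay compound 2 gives 86000 nM. Among the measured compounds shown here, that is the only finite value shown, so compound 2 stands as the one compound with a measured number, while the other sits at the limit of > 300000 nM in this assay, at which 1 of the 2 values shown sits.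

Compound 3, not yet measured, has the structure `Cc1c(C)c2c(c(C)c1OC(=O)CCC(=O)O)CCC(C)(C(=O)NC1CC(C)(C)N([O])C1(C)C)O2`. It differs from compound 2 by one oxygen atom in place of a group of 11 heavy atoms (8 carbon, 2 nitrogen, 1 oxygen; one five-membered non-aromatic ring with 1 hetero atom), on a carbonyl carbon. For the measured compounds named here, no measured pair here carries exactly this change, so the size of the step is not known from the data. The expectation is that the step of a 2.9-fold higher number from compound 2 to compound 3 (0.46 log units; beyond the scatter) weakens inhibition beyond the scatter, with a fair chance that only a limit will be reported. For compound 3 the estimate in this assay is 250000 nM, with a range from 100000 nM to 600000 nM.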

Compound 3, half-maximal inhibitory concentration: > 300000 nM
Compound 3 ended at the assay's limit; the forecaster's own chance of this, stated with the estimate: 55%; middle value at least 1.2-fold (0.07 log units) from the limit.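

In this assay, putting a hydroxy in place of the group of 11 heavy atoms, with its five-membered non-aromatic ring, on this carbonyl carbon gives an at least 3.4-fold higher number from compound 2 to compound 3 (0.54 log units; beyond the scatter), a change beyond the scatter. Compound 3 gives > 300000 nM, which is a limit of the assay and not a number. Compound 2, the only one of the three that carries this ring-bearing group on the carbonyl carbon, is now also the only one with a finite value, while the hydroxy-bearing compounds share the limit: the limit of > 300000 nM in this assay, at which 2 of the 3 values shown sit.

The step from compound 1 to compound 3, which swaps a six-membered for a five-membered non-aromatic ring on the amide-type nitrogen, cannot be read, so these results do not show whether that ring size matters. From the compounds shown here alone, it also remains open whether the finite value of compound 2 depends on the full ring-bearing group, or whether a smaller group on the same carbonyl carbon, such as a methyl ester or a plain amide, would also give a finite value.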